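A dioxolane series and the cost of a hydroxymethyl group

This account rests on a few compounds, and the source may have more. Where it says the series, first, only, none or still open, it means among the compounds named here.

Compound 1 `CC1(C)OCC(Cn2cc(Cn3c4c(c5ccccc53)C(=O)c3c[n+]([O-])c5ccccc5c3C4=O)nn2)O1` is the reference point here. In a functional assay on SH-SY5Y cells (Homo sapiens) for cytotoxicity, read by MTT assay, with a stated time of 72 h (a lower number here means a stronger inhibitor, a higher number a weaker inhibitor), compound 1 gives 230 nM. Compound 2 `CC1(C)O[C@@H](CO)[C@H](Cn2cc(Cn3c4c(c5ccccc53)C(=O)c3c[n+]([O-])c5ccccc5c3C4=O)nn2)O1` carries the 5-(hydroxymethyl)-2,2-dimethyl-1,3-dioxolan-4-yl group in place of the 2,2-dimethyl-1,3-dioxolan-4-yl group on the saturated chain carbon bound to an aromatic nitrogen. For compound 2 this assay reports only a limit, > 1000 nM, not a number. For the measured compounds named here, the one measured step, an at least 4.3-fold higher number from compound 1 to compound 2 (0.63 log units; beyond the scatter), therefore shows that adding the hydroxymethyl group weakens the compound, though the size of that loss is not fixed because of the limit of > 1000 nM in this assay, at which 1 of the 2 values shown sits.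

Compound 3 `CC1(C)OC[C@@H](Cn2cc(Cn3c4c(c5ccccc53)C(=O)c3c[n+]([O-])c5ccccc5c3C4=O)nn2)O1` is not yet measured. Relative to compound 2 it undoes that change: 2,2-dimethyl-1,3-dioxolan-4-yl in place of 5-(hydroxymethyl)-2,2-dimethyl-1,3-dioxolan-4-yl on a saturated chain carbon bound to an aromatic nitrogen. Compound 3 is thus the same arrangement as compound 1, with the configuration of the dioxolane defined. The measured step from compound 1 to compound 2 bears directly on this, and reversing it leads one to expect a lower number, so the step of an at least 4.0-fold lower number from compound 2 to compound 3 (0.60 log units; beyond the scatter) is expected to recover roughly what compound 2 lost. Compound 3 is estimated at 250 nM in this assay, within a range from 110 nM to 600 nM.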

Compound 3, half-maximal inhibitory concentration: > 1000 nM
Compound 3: no number, only a limit; the forecaster's own chance of this, stated with the estimate: 10%; at least 4.0-fold (0.60 log units) between middle value and limit.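

In this assay compound 3 gives > 1000 nM, a limit and not a number, even though it carries the 2,2-dimethyl-1,3-dioxolan-4-yl group and no hydroxymethyl group. Losing the hydroxymethyl group therefore does not by itself bring back the reading of compound 1, and the step from compound 2 to compound 3 cannot be read, because of: the limit of > 1000 nM in this assay, at which 2 of the 3 values shown sit. The same atoms and bonds still give an at least 4.3-fold higher number from compound 1 to compound 3 (0.63 log units; beyond the scatter), so what counts at this position is not only which group is present, and the gap rests on: the fact that one of compounds 1 and 3 is drawn with a defined configuration and the other without, at the place where they differ.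

The compounds shown leave open whether the S configuration at the saturated ring carbon would account for the reading of compound 1, and how far compound 2 and compound 3 actually lie beyond their limits. They also leave open how an open diol chain or an amine in place of the dioxolane would behave on the saturated chain carbon bound to an aromatic nitrogen.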